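The source may report more compounds than this note shows. Statements on the series, on what has been measured and on what is new or still open speak of the compounds shown alone.

Measured in a functional assay on HT-29 cells (Homo sapiens) for cytotoxicity, read by XTT assay, with a stated time of 72 h; on this read-out higher numbers stand for weaker inhibition and lower numbers for stronger inhibition:
- Compound 1 `CC(C)=CCC/C=C(\C)Cc1c(O)cc(O)c2c(=O)c(OC/C=C(\C)CCC=C(C)C)c(-c3ccc(O)cc3)oc12`: 30000 nM
- Compound 2 `C=C1CC[C@H]2C(C)(C)CCC[C@]2(C)[C@H]1CC/C(C)=C/COc1cc(O)c2c(=O)c(OC/C=C(\C)CC[C@H]3C(=C)CC[C@H]4C(C)(C)CCC[C@]34C)c(-c3ccc(OC)cc3)oc2c1`: > 100000 nM, a limit of the assay and not a number

Going by the values given here, compound 1 is the only compound here with an actual number, so it cannot yet be ranked against a second measured value. In this assay, compound 1 gives 30000 nM, and this is the starting point for what follows.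

Compound 3 `CC(C)=CCC/C(C)=C/COc1c(-c2ccc(O)cc2)oc2cc(O)cc(O)c2c1=O` differs from compound 1 in one place: hydrogen in place of 2,7-dimethylocta-2,6-dien-1-yl on an aromatic carbon. Hydrogen takes the place of 2,7-dimethylocta-2,6-dien-1-yl on an aromatic carbon, ortho to a hydroxy group and para to a hydroxy group. The rest of the structure stays the same.

Among the compounds with values here, no measured pair shows what this change does on its own, so any forecast is uncertain. In this assay, within the data shown here, the expectation is for no step clearly beyond the usual scatter, with a slight lean towards weaker inhibition. The estimated change is a 1.3-fold higher number from compound 1 to compound 3 (0.12 log units; within the scatter), and it is expected to remain small. For compound 3 the estimate is 40000 nM, with an expected range from 12000 nM to 100000 nM.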

Compound 3, half-maximal inhibitory concentration: 25000 nM
For compound 3 the middle estimate is 1.6-fold (0.20 log units) above the measured one; measured number inside the range.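

In this assay, replacing the 2,7-dimethylocta-2,6-dien-1-yl group with hydrogen gives a 1.2-fold lower number from compound 1 to compound 3 (0.08 log units; within the scatter). Going by these compounds alone, this is the first measured look at this position, and it shows that an aromatic carbon ortho to a hydroxy group and para to a hydroxy group can carry either this chain of 10 carbon atoms or a bare hydrogen with no difference this assay can separate, so the chain is not needed for the activity seen with compound 1. The comparison rests on two real numbers, and the only compound shown with a limit rather than a number is compound 2: the limit of > 100000 nM in this assay, at which 1 of the 3 values shown sits.

As far as these compounds go, only hydrogen and this one long chain have been compared at this position, so it remains open whether a methyl group, a shorter chain, an amine or a carboxylic acid there would leave the value unchanged or move it beyond the scatter. The result also says nothing about what the chain on the ether oxygen or the hydroxy groups of the shared core contribute, since neither changes in this step.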